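This account rests on a few compounds, and the source may have more. Where it says the series, first, only, none or still open, it means among the compounds named here.

Compounds measured so far:

Compound 1, `Cc1cc(C(=O)Nc2c(F)cccc2F)nn1Cc1cc(Cl)ccc1OCc1ccccc1`, gives 10 nM in an assay on CHO-K1 cells for displacement of a labelled ligand from prostaglandin E2 receptor EP1 subtype (Homo sapiens); on this read-out higher numbers stand for weaker inhibition and lower numbers for stronger inhibition.
Compound 2, `Cc1cc(C(=O)NCc2ccccn2)nn1Cc1cc(Cl)ccc1OCc1ccccc1`, gives 25.1 nM in this assay.
Compound 3, `Cc1cc(C(=O)NCc2cccnc2)nn1Cc1cc(Cl)ccc1OCc1ccccc1`, gives 50.1 nM in this assay.

Compound 3 holds the highest of the three numbers. Its nearest neighbour is compound 2, and the step of a 2.0-fold higher number from compound 2 to compound 3 (0.30 log units; within the scatter) is within the scatter of the method, so the two are not ordered by these data. The step of a 5.0-fold higher number from compound 1 to compound 3 (0.70 log units; beyond the scatter) is beyond the scatter, as is the step of a 2.5-fold higher number from compound 1 to compound 2 (0.40 log units; beyond the scatter).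

Compound 4, `Cc1cc(C(=O)NCc2ccncc2)nn1Cc1cc(Cl)ccc1OCc1ccccc1`, has not yet been measured. It differs from compound 3 in one place: pyridin-4-yl in place of pyridin-3-yl on a saturated chain carbon bound to an amide-type nitrogen.

Among the measured compounds shown here, only one measured step bears directly on this kind of change, the move of the ring nitrogen within the same ring in a 2.0-fold higher number from compound 2 to compound 3 (0.30 log units; within the scatter), which stayed within the scatter. The larger steps from compound 1 concern a different group on the amide nitrogen and speak less to this case. On that basis no step beyond the scatter is expected in this assay for the change from compound 3 to compound 4, and the expected step is a 1.0-fold lower number from compound 3 to compound 4 (0.00 log units; within the scatter).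

Compound 4 is therefore estimated to give 50 nM in this assay, with an expected range from 20 nM to 130 nM.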

Compound 4, half-maximal inhibitory concentration: 79.4 nM
Estimate against measurement, compound 4: 1.6-fold (0.20 log units) below; low and high end bracket the measured number.
By their numbers in this assay, from the lowest: compound 1; then compounds 2, 3 and 4 (each within the scatter of the next, the first and the last beyond it).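

In this assay, moving the ring nitrogen one place further gives a 1.6-fold higher number from compound 3 to compound 4 (0.20 log units; within the scatter), so pyridin-3-yl and pyridin-4-yl on this saturated chain carbon are not ordered by these data. The new compound does show that the position of the ring nitrogen can register here: the full move from pyridin-2-yl to pyridin-4-yl gives a 3.2-fold higher number from compound 2 to compound 4 (0.50 log units; beyond the scatter), although neither of the two smaller moves that make it up is beyond the scatter. Compound 4 also sets the widest gap from the 2,6-difluorophenyl amide, at a 7.9-fold higher number from compound 1 to compound 4 (0.90 log units; beyond the scatter), so all three (pyridinyl)methyl amides now lie beyond the scatter from compound 1. Nothing shown here accounts for these differences.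

Each step from compound 1 swaps the ring and adds a chain carbon in a single move, so a plain benzyl group on the amide-type nitrogen would be needed to separate the two changes. On these data alone, how a 2-(pyridin-2-yl)ethyl chain, or a 2,6-difluorobenzyl group, would fall also remains open.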